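Acylating the terminal ring amine of compound 1

This account rests on a few compounds, and the source may have more. Where it says the series, first, only, none or still open, it means among the compounds named here.

Compound 1 `CCN(CC)c1ccc2cc(C(=O)c3ccc(N4CCN(C(=O)CN5CCNCC5)CC4)cc3)oc2c1` carries a free amine nitrogen in its terminal six-membered ring. In an ADME assay on L02 cells (Homo sapiens) for cytotoxicity, read by MTT assay, with a stated time of 48 h (a lower number here means a stronger inhibitor, a higher number a weaker inhibitor), compound 1 gives only a limit, > 100000 nM, and not a number. Among the measured compounds shown here, that limit is the limit of > 100000 nM in this assay, at which 1 of the 2 values shown sits, and compound 1 is the one of the two values that sits on it. Compound 2 `CCN(CC)c1ccc2cc(C(=O)c3ccc(N4CCN(C(=O)CN5CCN(C(=O)CCl)CC5)CC4)cc3)oc2c1` differs from compound 1 by a (chloromethyl)carbonyl group on that same ring nitrogen, and in this assay compound 2 gives 20900 nM. For the measured compounds named here, the only measured step, an at least 4.7-fold lower number from compound 1 to compound 2 (0.67 log units; beyond the scatter), shows that capping the free ring nitrogen moved the number down beyond the scatter.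

Compound 3 `CCN(CC)c1ccc2cc(C(=O)c3ccc(N4CCN(C(=O)CN5CCN(C(=O)/C=C/c6ccccc6)CC5)CC4)cc3)oc2c1` is not yet measured. Relative to compound 1 the change is (2-phenylethenyl)carbonyl in place of hydrogen on an amine nitrogen in a ring. Because it falls on the same ring nitrogen as the change behind an at least 4.7-fold lower number from compound 1 to compound 2 (0.67 log units; beyond the scatter), that step is the one that bears on it, and a lowering of at least modest size in this assay is expected, though the larger group makes the size uncertain. The expected step is an at least 6.6-fold lower number from compound 1 to compound 3 (0.82 log units; beyond the scatter). Compound 3 is estimated at 15000 nM, within 5000 nM to 60000 nM.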

Compound 3, half-maximal inhibitory concentration: > 100000 nM
Compound 3: a limit, no number; the forecaster's own chance of this, stated with the estimate: 15%; middle value at least 6.6-fold (0.82 log units) from the limit.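

Capping the ring nitrogen does not by itself lower the number in this assay: placing 2-phenylethenyl instead of chloromethyl on the carbonyl carbon gives an at least 4.7-fold higher number from compound 2 to compound 3 (0.67 log units; beyond the scatter). The earlier step came with capping the free nitrogen. These compounds show that the result differs with what the carbonyl carries at this position, and among the three compounds only compound 2, with chloromethyl, gives a number. Compound 3 gives a limit and not a number, as compound 1 does, so the step between those two cannot be read: the limit of > 100000 nM in this assay, at which 2 of the 3 values shown sit.

On these data alone, how far compound 1 and compound 3 lie past that limit remains unknown, so the two cannot be ordered. The compounds shown also leave open whether the chlorine-bearing carbon is what matters, since they do not tell how a plain acetyl group, a bromomethyl group on the same carbonyl, or a saturated 2-phenylethyl chain in place of 2-phenylethenyl would read on this ring nitrogen.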